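Adding methoxy to compound 3

This account rests on a few compounds, and the source may have more. Where it says the series, first, only, none or still open, it means among the compounds named here.

compound 1 `CCC1=C(O)c2c(oc(-c3ccc(O)cc3)cc2=O)C(CC)(CC)C1=O`: 20.6 uM
compound 2 `CCC1=C(O)c2c(oc(-c3ccc(CBr)cc3)cc2=O)C(CC)(CC)C1=O`: > 46.5 uM
compound 3 `CCC1=C(O)c2c(oc(-c3ccccc3C)cc2=O)C(CC)(CC)C1=O`: 40.9 uM

In a functional assay on KB cells (Homo sapiens) for antiproliferative activity, read by sulforhodamine B assay, with a stated time of 3 days (a higher number here means that more compound is needed for the effect, a lower number that less compound is needed), compound 3 gives 40.9 uM as its value. The reading for compound 2, > 46.5 uM, is a limit of the assay and not a number. Among the compounds with values here, the one comparison between true numbers is a 2.0-fold higher number from compound 1 to compound 3 (0.30 log units; within the scatter), so compound 3 has no clear rank.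

Compound 4 `CCC1=C(O)c2c(oc(-c3ccc(OC)cc3C)cc2=O)C(CC)(CC)C1=O` carries a single change, (methoxy in place of hydrogen on an aromatic carbon), which is methoxy in place of hydrogen on an aromatic carbon, para to a large group. The 2-methylphenyl thus becomes 4-methoxy-2-methylphenyl.

Within the data shown here, two measured steps concern this part of the molecule. Replacing the hydroxy group gave an at least 2.2-fold higher number from compound 1 to compound 2 (0.35 log units; beyond the scatter), a result that rests on a limit. Replacing 4-hydroxyphenyl with 2-methylphenyl gave a 2.0-fold higher number from compound 1 to compound 3 (0.30 log units; within the scatter). Neither step tests methoxy itself, and the second suggests only a small effect from this region. The expected change is therefore a 1.3-fold lower number from compound 3 to compound 4 (0.11 log units; within the scatter), which means no shift beyond the scatter is anticipated. In this assay the estimated value for compound 4 is 32 uM, with an expected range from 14 uM to 65 uM.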

Compound 4, concentration for half-maximal effect: 20.9 uM
Compound 4: the middle estimate sits 1.5-fold (0.19 log units) above what was measured; the measured number falls inside the stated range.
By their numbers in this assay, from the lowest: compounds 1, 4 and 3 (each within the scatter of the next). At a limit, above all of these: compound 2.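

In this assay, within the data shown here, methoxy para to a large group is the first substituent added to the 2-methylphenyl itself, and a 2.0-fold lower number from compound 3 to compound 4 (0.29 log units; within the scatter) shows that this addition does not move the number beyond the scatter. The 4-methoxy-2-methylphenyl and 4-hydroxyphenyl groups cannot be told apart in this assay, at a 1.0-fold higher number from compound 1 to compound 4 (0.01 log units; within the scatter). The only new step beyond the scatter, an at least 2.2-fold lower number from compound 2 to compound 4 (0.34 log units; beyond the scatter), rests on a limit of the assay and not a number, so only its floor is known: the limit of > 46.5 uM in this assay, at which 1 of the 4 values shown sits.

The compounds shown leave open whether an amine or a carboxylic acid at this same position would shift the number beyond the scatter. They also leave open whether a longer chain such as ethoxy in place of methoxy would do so.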